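From Ethyl to Propyl in a Short Series

The compounds below may be only part of what the source reports. "The series", "measured", "known", "first", "only" and "open" are said of these compounds alone.

In a functional assay on HepG2 cells (Homo sapiens) for antiproliferative activity, read by CCK-8 assay, with a stated time of 72 h (a higher number here means a weaker inhibitor, a lower number a stronger inhibitor), compound 1 (`Nc1ccccc1NC(=O)c1ccc(COc2ccc(Br)cc2)cc1`) gives only a limit of > 32000 nM and no number. Compound 2 (`Nc1ccccc1NC(=O)c1ccc(COc2ccccc2)cc1`) reads 6700 nM and compound 3 (`CCc1ccc(OCc2ccc(C(=O)Nc3ccccc3N)cc2)cc1`) reads 6960 nM in this assay, so compound 3 stands level with compound 2, within the scatter.

Compound 4 (`CCCc1ccc(OCc2ccc(C(=O)Nc3ccccc3N)cc2)cc1`) carries methyl in place of hydrogen on a saturated chain carbon, two bonds along the chain from an aromatic carbon, which takes ethyl to propyl. The two steps away from bromo (an at least 4.7-fold lower number from compound 1 to compound 2 (0.67 log units; beyond the scatter)) and (an at least 4.5-fold lower number from compound 1 to compound 3 (0.66 log units; beyond the scatter)) both go beyond the scatter, but each rests on a limit. Within the data shown here, the closest precedent is ethyl in place of hydrogen (a 1.0-fold higher number from compound 2 to compound 3 (0.02 log units; within the scatter)), which stays within the scatter.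

One further methyl is therefore expected to cause no change beyond the scatter, and the expected step (a 1.1-fold higher number from compound 3 to compound 4 (0.03 log units; within the scatter)) is correspondingly small. Compound 4 is estimated at 7500 nM in this assay, with 3000 nM to 20000 nM as its expected range.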

Compound 4, half-maximal inhibitory concentration: 4750 nM
Estimate against measurement, compound 4: 1.6-fold (0.20 log units) above; the measured number falls inside the stated range.
By their numbers in this assay, from the lowest: compounds 4, 2 and 3 (each within the scatter of the next). At a limit, above all of these: compound 1.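

In this assay the change from ethyl to propyl gives a 1.5-fold lower number from compound 3 to compound 4 (0.17 log units; within the scatter) and propyl in place of hydrogen gives a 1.4-fold lower number from compound 2 to compound 4 (0.15 log units; within the scatter), so neither the added methyl nor the whole propyl group takes the number beyond the scatter. Hydrogen, ethyl and propyl at this place thus read alike, and only bromo stands apart, with an at least 6.7-fold lower number from compound 1 to compound 4 (0.82 log units; beyond the scatter) as the step away from it. That step has a bound but no exact size, as compound 1 is held only at a limit: the limit of > 32000 nM in this assay, at which 1 of the 4 values shown sits.

Still open, on these data alone, is whether a longer chain such as butyl would stay level with these compounds. Also open, as far as these compounds go, is how an amine, a carboxylic acid or a smaller halogen such as chloro would read at the same place.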